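The source may report more compounds than this note shows. Statements on the series, on what has been measured and on what is new or still open speak of the compounds shown alone.

Measured so far in a functional assay on NCI-H1299 cells (Homo sapiens) for cytotoxicity, read by a luciferase reporter and CellTiter-Glo, with a stated time of 72 h; on this read-out lower numbers stand for stronger inhibition and higher numbers for weaker inhibition
Compound 1 `CC(C)(C)C1=NN(c2ccc(Cl)cc2)C(c2ccc(Cl)cc2)C1` gives 19300 nM
Compound 2 `CC(C)(C)C1=NN(c2ccc(Br)cc2)C(c2ccc(Br)cc2)C1` gives "not determined" (no result reported)

Compound 2 is recorded as "not determined" (no result reported) and has no single number, so it cannot be placed against the other compound. Compound 1 alone supplies a figure, 19300 nM in this series. The next structure is compound 3 `CC(C)(C)C1=NN(c2ccc(Br)cc2)C(c2ccc(Cl)cc2)C1` and it is reached from compound 2 by a single swap. That swap, (chloro in place of bromo on an aromatic carbon), puts chloro in place of bromo on an aromatic carbon, para to a large group. Among the measured compounds shown here, no measured step shows what such a swap does in this assay and the expectation is therefore tentative: no shift beyond the usual scatter, in either direction. For the measured compounds named here, the estimate leans on compound 1 with its 19300 nM as the only available number. The value expected for compound 3 is 19000 nM, within an estimated range of 9000 nM to 40000 nM.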

Compound 3, half-maximal inhibitory concentration: 19400 nM
Estimate against measurement, compound 3: 1.0-fold (0.01 log units) below; measured number inside the range.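

In this assay, the series gains its first readable halogen swap on an aromatic carbon, para to a large group: bromo in place of chloro gives a 1.0-fold higher number from compound 1 to compound 3 (0.00 log units; within the scatter), so at this position the two halogens are not told apart by this read-out. The swap linking compound 2 and compound 3 lies on the other aromatic ring and cannot be read, since compound 2 has no number. Nothing available here offers an explanation for this result.

The compounds shown leave open whether any group other than these two halogens, such as an amine, a carboxylic acid or a methoxy group, would move the number at this position. They also leave open what a swap on the other aromatic ring does.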